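Adding one fluoro group to compound 2

The source may hold more compounds than are shown below. What is called first, only, known or untested is meant among the compounds shown, and "the series" means these compounds.

In a physicochemical assay for solubility, read by nephelometry, measured as kinetic solubility, at pH 6.5, tested at 10 mg/mL (a lower number here means a less soluble compound, a higher number a more soluble compound), compound 1 (`Cc1c(F)cccc1C(=O)Nc1cc(Cl)ccn1`) gives 12.5 ug/mL and compound 2 (`Cc1ccnc(NC(=O)c2ccccc2C)c1`) gives 25 ug/mL as its reading. Within the data shown here, these two numbers lie within the usual scatter of each other, which leaves compound 2 level with the only other measured compound. Compound 3 (`Cc1ccnc(NC(=O)c2cccc(F)c2C)c1`) alters compound 2 in one place (fluoro in place of hydrogen on an aromatic carbon), with fluoro in place of hydrogen on an aromatic carbon. Among the measured compounds shown here, no measured pair shows this change alone. What is expected in this assay is a 1.4-fold lower number from compound 2 to compound 3 (0.14 log units; within the scatter) and no more than that, a slight fall that stays within the scatter. For compound 3 the estimate is 18 ug/mL with an expected range from 6 ug/mL to 50 ug/mL on this measure.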

Compound 3, solubility: 25 ug/mL
Estimate against measurement, compound 3: 1.4-fold (0.14 log units) below; measured number inside the range.
By their numbers in this assay, from the lowest: compounds 1, 2 and 3 (each within the scatter of the next).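

Fluoro in place of hydrogen on an aromatic carbon, ortho to a methyl group, gives no change at the digits printed from compound 2 to compound 3 (within the scatter) in this assay and this is the first reading of that change alone. Methyl in place of chloro on an aromatic carbon gives a 2.0-fold higher number from compound 1 to compound 3 (0.30 log units; within the scatter) in this assay and this is also the first reading of that change alone. Neither change can be told apart from the usual scatter of repeated measurements. On these data alone, how an amine or a carboxylic acid at the fluoro position would read remains open. No measurement at hand bears on the cause of these readings.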